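The source may report more compounds than this note shows. Statements on the series, on what has been measured and on what is new or still open speak of the compounds shown alone.

Two compounds of this series have numbers in an assay on HEK293 cells for displacement of a labelled ligand from 5-hydroxytryptamine receptor 7 (Rattus norvegicus); on this read-out higher numbers stand for weaker inhibition and lower numbers for stronger inhibition. Compound 1 `COc1ccccc1N1CCN(CCCC(=O)NC2CCCc3cccc(OC)c32)CC1` gives 154 nM. Compound 2 `O=C(CCCCCN1CCN(c2noc3ccccc23)CC1)NC1CCCc2ccccc21` gives 125 nM in this assay; it has the lower of the two numbers, but its gap to compound 1 lies within the scatter, so the two cannot be ordered against each other. Compound 3 `CC(=O)c1cccc(N2CCN(CCCCCC(=O)NC3CCCc4ccccc43)CC2)c1` is not yet measured. It differs from compound 2 at one place: a group of 9 heavy atoms (8 carbon, 1 oxygen; one six-membered aromatic ring of carbon only) in place of a group of 9 heavy atoms (7 carbon, 1 nitrogen, 1 oxygen; one five-membered aromatic ring with 2 hetero atoms, one six-membered aromatic ring of carbon only), on an amine nitrogen in a ring. Within the data shown here, no step between measured compounds shows what such a swap on the amine nitrogen in a ring does in this assay, so the direction of the change is open and the bounds must stay wide. A moderate rise in the number is expected, since compound 2 gives 125 nM with the leaving group in place. The expected step is a 2.4-fold higher number from compound 2 to compound 3 (0.38 log units; beyond the scatter). For compound 3 the estimate in this assay is 300 nM, within 80 nM to 1200 nM.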

Compound 3, inhibition constant: 496 nM
For compound 3 the middle estimate is 1.7-fold (0.22 log units) below the measured one; measured number inside the range.
By their numbers in this assay, from the lowest: compounds 2 and 1 (each within the scatter of the next); then compound 3.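

Among these compounds, on an amine nitrogen in a ring, 3-acetylphenyl in place of the two-ring group of compound 2 gives a 4.0-fold higher number from compound 2 to compound 3 (0.60 log units; beyond the scatter) in this assay, the first reading of a change at this position. The two groups have the same count of 9 heavy atoms, so this position responds to more than that count: the entering group has no five-membered aromatic ring with 2 hetero atoms, one hydrogen-bond acceptor fewer, and a double bond outside aromatic rings. Nothing available explains the size or direction of this step.

A single step cannot separate the loss of the five-membered ring from the gain of the acetyl group; an unsubstituted phenyl, or a nitrile in place of the acetyl, would divide the two. Compound 1 differs from compound 2 and compound 3 in more than one place, so the effect of chain length at this amide stays unresolved.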